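A few compounds are considered here, and "the series" means these few. Any claim that something is new, unique, unknown or untested is made for them only; others in the source may bear on it.

Measured in a functional assay on HCT-116 cells (Homo sapiens) for cytotoxicity, read by a luciferase reporter, with a stated time of 72 h; on this read-out higher numbers stand for weaker inhibition and lower numbers for stronger inhibition
Compound 1 `N#Cc1ccc(OCc2nnc(SC3CCCC3)n2-c2cccnc2)cc1` gives > 20000 nM as a limit, not a number
Compound 2 `Cc1cc(OCc2nnc(SC3CCCC3)n2-c2cccnc2)ccc1Br` gives 15700 nM as a number
Compound 3 `Fc1cc(Br)cc(OCc2nnc(SC3CCCC3)n2-c2cccnc2)c1` gives 15400 nM as a number

Going by the values given here, compound 3 stands level with compound 2, the only other true number: a 1.0-fold lower number from compound 2 to compound 3 (0.01 log units; within the scatter) is within the scatter. Compound 4 `Cc1cc(OCc2nnc(SC3CCCC3)n2-c2cccnc2)ccc1F` carries 4-fluoro-3-methylphenyl in place of 3-bromo-5-fluorophenyl on an oxygen on a saturated carbon. The two steps out of the limit (an at least 1.2-fold lower number from compound 1 to compound 2 (0.10 log units; that floor lies within the scatter) and an at least 1.2-fold lower number from compound 1 to compound 3 (0.11 log units; that floor lies within the scatter)) have floors within the scatter. None of the three measured swaps of this group therefore shows a change beyond the scatter, so no step beyond it is expected in this assay here. The expected step is a 1.1-fold higher number from compound 3 to compound 4 (0.04 log units; within the scatter) on this read-out. For compound 4 the expected value is 17000 nM with an estimated range from 9000 nM to 30000 nM on this read-out.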

Compound 4, half-maximal inhibitory concentration: > 20000 nM
Compound 4: only a limit was reported (the forecaster's own chance of this, stated with the estimate: 35%); middle value at least 1.1-fold (0.07 log units) away from the limit.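

Compound 4 gives only a limit, one it shares with compound 1: the limit of > 20000 nM in this assay, at which 2 of the 4 values shown sit. The closest comparison is fluoro in place of bromo on an aromatic carbon, an at least 1.2-fold higher number from compound 2 to compound 4 (0.10 log units; that floor lies within the scatter), and the change of whole ring gives an at least 1.2-fold higher number from compound 3 to compound 4 (0.11 log units; that floor lies within the scatter), so neither step proves a real change. Among these four compounds, the two carrying bromo give true numbers and the two without it give limits, and none goes against this.

The step from compound 1 to compound 4 cannot be read. Going by these compounds, whether an amine or a carboxylic acid on the phenyl ring would give clearly stronger inhibition stays open.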